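This account rests on a few compounds, and the source may have more. Where it says the series, first, only, none or still open, it means among the compounds named here.

Three compounds were measured in a functional assay on U-87MG ATCC cells for antiproliferative activity against U-87 MG (Homo sapiens), read by MTT assay, with a stated time of 48 h, tested at 100 uM; a higher number here means a weaker effect of the compound at the concentration tested, a lower number a stronger effect. Compound 3 `Cc1nc(-c2ccccc2)sc1C(=O)CSc1nc(-c2ccc(Cl)cc2)c(C#N)c(=O)[nH]1` gives 22.5%, while compound 1 `COc1ccc(-c2nc(SCC(=O)c3sc(-c4ccccc4)nc3C)[nH]c(=O)c2C#N)cc1` gives 1.08%. Compound 1 differs from compound 3 by methoxy in place of chloro on an aromatic carbon, and this change gave a number 21.4 percentage points lower from compound 3 to compound 1 (beyond the scatter). Compound 2 `Cc1nc(-c2ccc(Cl)cc2)sc1C(=O)CSc1nc(N)c(C#N)c(-c2ccc(Cl)cc2)n1` gives 1.65%; its value and that of compound 1 lie within the scatter of each other. The difference between the core of compound 2 and the core of compound 3 is not broken down here. Compound 4 `COc1ccc(-c2nc(SCC(=O)c3sc(-c4ccc(Cl)cc4)nc3C)nc(N)c2C#N)cc1` has not yet been measured; it differs from compound 2 by methoxy in place of chloro on an aromatic carbon, the same change as from compound 3 to compound 1. The step is expected to be only a number 0.5 percentage points lower from compound 2 to compound 4 (within the scatter), far smaller than the earlier one, because compound 2 already gives 1.65% and leaves little room. Compound 4 is therefore estimated at 1.2%, between 0.3% and 5%.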

Compound 4, a percentage reported as activity, at one concentration (the size of the read-out at that concentration, not a potency): 0.79%
Compound 4: middle estimate off by 0.4 percentage points, on the high side; low and high end bracket the measured number.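

In this assay, methoxy in place of chloro on an aromatic carbon gave a number 0.9 percentage points lower from compound 2 to compound 4 (within the scatter), so no effect of the change can be read on this core. The size of the step therefore did not carry over from one core to the other: the same change on two cores in this assay, a number 21.4 percentage points lower (beyond the scatter) from compound 3 to compound 1 and a number 0.9 percentage points lower (within the scatter) from compound 2 to compound 4, 20.6 percentage points apart, beyond the scatter of two such steps

This does not show why the steps differ, since two cores give no rule for the series, and a read-out as low as that of compound 2 at 1.65% may leave any further step unseen.

The compounds shown leave open how a fluoro, a methyl or a dimethylamino group would behave at this place on either core. They also speak only of a stronger or weaker effect at the one concentration tested, and leave open how the compounds would compare at any other concentration.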